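Shortening the ester chain from dodecyl to hexyl

The source may hold more compounds than are shown below. What is called first, only, known or untested is meant among the compounds shown, and "the series" means these compounds.

Compound 1 `CC(C)c1cccc(C(C)C)c1NC(=O)CC(=O)O` carries the free acid. In an assay on microsomes from intestine for inhibition of acyl-CoA:cholesterol acyltransferase (Oryctolagus cuniculus) (a lower number here means a stronger inhibitor, a higher number a weaker inhibitor), compound 1 reaches only a limit, > 5000 nM, which is the limit of > 5000 nM in this assay, at which 1 of the 2 values shown sits. Compound 2 `CCCCCCCCCCCCOC(=O)CC(=O)Nc1c(C(C)C)cccc1C(C)C` is the dodecyl ester of that acid. In this assay compound 2 gives 11 nM. Within the data shown here, this is the only number in the set, the one other value, that of compound 1, being a limit, so compound 2 stands alone as the measured reference. Compound 3 `CCCCCCOC(=O)CC(=O)Nc1c(C(C)C)cccc1C(C)C` differs from compound 2 by hydrogen in place of hexyl on a saturated chain carbon, six bonds along the chain from an oxygen next to a carbonyl group. Among the measured compounds shown here, no measured pair shows a change of exactly this kind, so the size of the step cannot be read from the data. The contrast between compound 1 and compound 2 at 11 nM suggests the ester chain carries much of the inhibition, and the author expects the shorter hexyl chain to weaken it beyond the scatter, with an expected step of a 14-fold higher number from compound 2 to compound 3 (1.13 log units; beyond the scatter). Compound 3 is therefore estimated at 150 nM, with a range from 30 nM to 1500 nM.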

Compound 3, half-maximal inhibitory concentration: 810 nM
The estimate for compound 3 lay 5.4-fold (0.73 log units) below the measured number; measured number inside the range.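

The chain length at this position turns out to matter strongly: removing the outer hexyl portion of the dodecyl ester gives, in this assay, a 74-fold higher number from compound 2 to compound 3 (1.87 log units; beyond the scatter), so the outer part of the dodecyl chain counts for a large share of the inhibition that compound 2 shows. Compound 1 stands at > 5000 nM, which is a limit of the assay and not a number: the limit of > 5000 nM in this assay, at which 1 of the 3 values shown sits. The hexyl ester nevertheless keeps measurable inhibition, with an at least 6.1-fold lower number from compound 1 to compound 3 (0.79 log units; beyond the scatter), which shows that placing hexyl on an oxygen next to a carbonyl group already moves the free acid beyond the scatter, although the full size of that step cannot be read from a limit.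

With only the hexyl and dodecyl esters measured, the compounds shown leave open whether inhibition climbs evenly between these two lengths or changes abruptly at an octyl or decyl chain, and whether a longer chain such as hexadecyl would go further still. They also leave open whether the ester oxygen itself is needed, since an amide in that place, carrying the same dodecyl chain, does not appear among them.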